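Methyl to hydroxy on the pendant phenyl of a urea series

A few compounds are considered here, and "the series" means these few. Any claim that something is new, unique, unknown or untested is made for them only; others in the source may bear on it.

Compound 1 `COc1cc(NC(=O)N2N=C(c3cc4ccccc4o3)CC2c2ccc(O)c(OC)c2)ccc1O`: 12000000 nM
Compound 2 `COc1cc(C2CC(c3cc4ccccc4o3)=NN2C(=O)Nc2ccc(O)c(O)c2)ccc1O`: 11000000 nM
Compound 3 `COc1cc(C2CC(c3cc4ccccc4o3)=NN2C(=O)Nc2ccc(C)cc2)ccc1O`: 44000000 nM

In a functional assay on microsomes from liver (Rattus norvegicus, strain Wistar) for inhibition, with a stated time of 15 min (on this read-out lower numbers stand for stronger inhibition and higher numbers for weaker inhibition), compound 3 gives the highest number of the three, with compound 1 nearest (a 3.7-fold higher number from compound 1 to compound 3 (0.56 log units; beyond the scatter)) and compound 2 furthest (a 4.0-fold higher number from compound 2 to compound 3 (0.60 log units; beyond the scatter)). Compound 4 `COc1cc(C2CC(c3cc4ccccc4o3)=NN2C(=O)Nc2ccc(O)cc2)ccc1O` is not yet measured; it differs from compound 3 by hydroxy in place of methyl on an aromatic carbon. Both measured steps bear on this change: in each, a 4-methylphenyl replacing a hydroxy-bearing phenyl raised the number modestly, so reintroducing a hydroxy is expected to lower it by a comparable, modest margin. Compound 4 is therefore expected to reach 15000000 nM, within 7000000 nM to 35000000 nM, a step of a 2.9-fold lower number from compound 3 to compound 4 (0.47 log units; beyond the scatter).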

Compound 4, half-maximal inhibitory concentration: 15000000 nM
Estimate against measurement, compound 4: no gap at the digits printed; low and high end bracket the measured number.
By their numbers in this assay, from the lowest: compounds 2, 1 and 4 (each within the scatter of the next); then compound 3.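

In this assay, the hydroxy on the 4-hydroxyphenyl group alone is enough to account for the step from 4-methylphenyl (a 2.9-fold lower number from compound 3 to compound 4 (0.47 log units; beyond the scatter)). Adding a further hydroxy or methoxy to that ring brings no change beyond the scatter (a 1.4-fold higher number from compound 2 to compound 4 (0.13 log units; within the scatter); a 1.3-fold higher number from compound 1 to compound 4 (0.10 log units; within the scatter)). Nothing available explains this result. From the compounds shown here alone, whether an amine or a carboxylic acid on that aromatic carbon would match the hydroxy remains open. So does whether a methoxy there, without the hydroxy, would serve equally well.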